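The source may hold more compounds than are shown below. What is called first, only, known or untested is meant among the compounds shown, and "the series" means these compounds.

Measured so far:
compound 1, `N[C@H]1CC[C@H](Nc2ccc3ncc(-c4cnc(Nc5ncccc5F)nc4)n3n2)CC1` — 0.2
compound 2, `N[C@H]1CC[C@H](Nc2ccc3ncc(-c4cnc(NCc5ccccn5)nc4)n3n2)CC1` — 0.4

Among the measured compounds shown here, both compounds share one core and have been measured in a physicochemical assay for lipophilicity; a higher number here means a more lipophilic compound, a lower number a more polar compound. In this assay compound 1 gives 0.2, the lower of the two numbers; compound 2 gives 0.4. For the measured compounds named here, the only measured step between them, a number 0.20 log units higher from compound 1 to compound 2 (within the scatter), changes the group on the nitrogen at the far end of the core and leaves the rest untouched.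

Compound 3, `Fc1cccnc1Nc1ncc(-c2cnc3ccc(NCCN4CCCC4)nn23)cn1`, has not yet been measured in this assay. It differs from compound 1 at the other end of the core: 2-(pyrrolidin-1-yl)ethyl in place of 4-aminocyclohexyl on a nitrogen on an aromatic ring. The two compounds share the same atoms, joined differently.

The measured step from compound 1 to compound 2 concerns a different part of the molecule, so it says little about the change toward compound 3. Going by the values given here, no measured pair shows what swapping these two groups does in this assay. On that thin basis, compound 3 is expected to give 0.6, within a range of 0 to 1.2. This estimate means an expected step of a number 0.40 log units higher from compound 1 to compound 3 (beyond the scatter), possibly beyond the scatter, though the direction is uncertain.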

Compound 3, distribution coefficient: 1.5
Compound 3: the middle estimate sits 0.90 log units below what was measured, outside the stated range (above it).
By their numbers in this assay, from the lowest: compounds 1 and 2 (each within the scatter of the next); then compound 3.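

In this assay, among the compounds shown here, the group on this nitrogen on an aromatic ring proves able to move the number strongly: putting 2-(pyrrolidin-1-yl)ethyl in place of 4-aminocyclohexyl gives a number 1.30 log units higher from compound 1 to compound 3 (beyond the scatter) and so opens a clear gap that the only earlier step, a number 0.20 log units higher from compound 1 to compound 2 (within the scatter) at the other end of the core, did not show. The size of the step is notable given that the two compounds have the same atoms, joined differently: a six-membered carbon ring bearing an amine leaves, and a chain ending in a five-membered ring enters. No supporting data bear on why this change has so large an effect.

A single swap cannot show whether the step follows the two-carbon chain, the pyrrolidine ring or the loss of the cyclohexane ring, and a 2-(dimethylamino)ethyl group or a longer chain ending in pyrrolidine on the same nitrogen would help separate these. From the compounds shown here alone, it also remains open whether the same swap gives a step of similar size when the (pyridin-2-yl)methyl group of compound 2 sits at the other end of the core.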